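Thiazole isomer swap on a bicyclic amine scaffold

The source may hold more compounds than are shown below. What is called first, only, known or untested is meant among the compounds shown, and "the series" means these compounds.

Measured compounds:
- Compound 1 `C[C@H]1[C@H](NCc2cncs2)C[C@H]2C[C@@H]1C2(C)C`, in an ADME assay on MDCK cells (Canis lupus familiaris) for cytotoxicity, read by microscopy, with a stated time of 48 h (on this read-out lower numbers stand for higher toxicity in this test and higher numbers for lower toxicity in this test), compound 1 gives > 100000 nM, which is a limit of the assay rather than a number.
- Compound 2 `CCCc1ccsc1CN[C@@H]1C[C@H]2C[C@@H]([C@H]1C)C2(C)C`, in this assay compound 2 gives 50000 nM.

Compound 1 sits at the edge of what this assay can report: its result is a limit only, not a measured number, and (the limit of > 100000 nM in this assay, at which 1 of the 2 values shown sits). Among the measured compounds shown here, no step between two measured compounds has been worked out here, so the two values shown can only be set side by side, and nothing more is said of the pair.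

Compound 3 `C[C@H]1[C@H](NCc2nccs2)C[C@H]2C[C@@H]1C2(C)C` is the compound still to be measured. It differs from compound 1 by 1,3-thiazol-2-yl in place of 1,3-thiazol-5-yl on a saturated chain carbon bound to an amine nitrogen. The atoms are the same and only the point of attachment of the ring changes. With compound 1 already at the assay limit, no step beyond the usual scatter is expected for this change. The step from compound 1 to compound 3 is estimated as a number no higher from compound 1 to compound 3 (the limit leaves the size open). For compound 3 the estimate in this assay is 100000 nM, with a range from 30000 nM to 300000 nM, and a real chance that only a limit is reported again.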

Compound 3, minimum cytotoxic concentration: > 100000 nM
Compound 3: no number, only a limit; the forecaster's own chance of this, stated with the estimate: 60%; the middle value sits exactly at the limit.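

In this assay compound 3 gives > 100000 nM, which is a limit of the assay and not a number. No step can be read between compound 1 and compound 3, because both results are limits: the limit of > 100000 nM in this assay, at which 2 of the 3 values shown sit.

The compounds shown leave open whether moving the thiazole attachment point changes the minimum cytotoxic concentration at all.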